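Swapping ethoxy for hydroxy on a purine-like scaffold

The compounds below may be only part of what the source reports. "The series", "measured", "known", "first", "only" and "open" are said of these compounds alone.

Measured in a functional assay on MOLT-4 cells (Homo sapiens) (on this read-out lower numbers stand for stronger inhibition and higher numbers for weaker inhibition), so far:
- compound 1 `Nc1ncnc2c1ncn2C[C@@H]1C[C@H](CO)c2ccccc21` gives 24 ug/mL
- compound 2 `Cn1ncc2c1[C@@H](CO[Si](c1ccccc1)(c1ccccc1)C(C)(C)C)C[C@H]2Cn1cnc2c(O)ncnc21` gives 3.2 ug/mL
- compound 3 `CCOc1ncnc2c1ncn2C[C@@H]1C[C@H](CO)c2ccccc21` gives 24 ug/mL

Compound 3 shares the highest number of the three with compound 1, while compound 2 has a clearly lower number. Compound 4 `OC[C@H]1C[C@@H](Cn2cnc3c(O)ncnc32)c2ccccc21` differs from compound 3 by hydrogen in place of ethyl on an oxygen on an aromatic ring, which also reads as ethoxy to hydroxy. Among the compounds with values here, one measured step bears on this group, ethoxy in place of amino on an aromatic carbon, and it shows no change at the digits printed from compound 1 to compound 3 (within the scatter). Within the data shown here, compound 2 also carries hydroxy, but it differs from compound 4 elsewhere too, and no measured step isolates hydroxy itself. Among the measured compounds shown here, with only that one step as a guide, no change beyond the scatter is expected in this assay, in either direction, though the uncertainty remains wide. The expected outcome is a 1.1-fold lower number from compound 3 to compound 4 (0.04 log units; within the scatter). The estimate for compound 4 is 22 ug/mL, with an expected range of 7 ug/mL to 70 ug/mL.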

Compound 4, half-maximal inhibitory concentration: 24 ug/mL
For compound 4 the middle estimate is 1.1-fold (0.04 log units) below the measured one; the measured number falls inside the stated range.
By their numbers in this assay, from the lowest: compound 2; then compounds 1, 3 and 4 (each within the scatter of the next).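

With hydroxy at this aromatic carbon, the position has now carried three groups, and in this assay swapping ethyl for hydrogen on the oxygen gives no change at the digits printed from compound 3 to compound 4 (within the scatter) and thus leaves the number where it stood. Hydroxy in place of amino gives no change at the digits printed from compound 1 to compound 4 (within the scatter) as well, so amino, ethoxy and hydroxy all read alike here, whereas the earlier compounds offered only the single comparison of amino with ethoxy. No measurement is available that would explain why these groups read alike and the result stands as an observation only.

From the compounds shown here alone, it remains open whether a group of a different kind at this position, such as a chlorine atom, a carboxylic acid or a longer alkoxy chain, would move the number beyond the scatter. Going by these compounds, it is also open whether this position would stay as insensitive on a core changed elsewhere.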